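The source may hold more compounds than are shown below. What is called first, only, known or untested is meant among the compounds shown, and "the series" means these compounds.

Measured in an ADME assay on Raji cells (Homo sapiens) for cytotoxicity, with a stated time of 72 h; a higher number here means that more compound is needed for the effect, a lower number that less compound is needed:

Compound 1 `Cc1cc(NC(=O)Nc2cccc(C(N)=O)c2)c2ccccc2n1`: > 25000 nM, a limit of the assay and not a number.
Compound 2 `Cc1cc(NC(=O)Nc2cccc(Cl)c2)c2ccccc2n1`: 18000 nM.

Going by the values given here, compound 2 holds the only actual number, 18000 nM. Compound 3 `Cc1cc(NC(=O)Nc2cccc(C(C)(C)C)c2)c2ccccc2n1` has tert-butyl in place of chloro on an aromatic carbon. Among the compounds with values here, the sole measured step, an at least 1.3-fold lower number from compound 1 to compound 2 (0.14 log units; that floor lies within the scatter), involves a different exchange and gives only a floor, so it offers little guidance. No step beyond the scatter is therefore expected in this assay. The expected change is a 1.3-fold lower number from compound 2 to compound 3 (0.11 log units; within the scatter). For compound 3 the estimated value is 14000 nM, within an expected range of 5000 nM to 30000 nM.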

Compound 3, half-maximal effective concentration: > 25000 nM
Compound 3: no number, only a limit; the forecaster's own chance of this, stated with the estimate: 25%; middle value at least 1.7-fold (0.25 log units) from the limit.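

Tert-butyl in place of chloro at this place on the aromatic ring gives an at least 1.3-fold higher number from compound 2 to compound 3 (0.14 log units; that floor lies within the scatter). In this assay, compound 3 gives > 25000 nM, a limit of the assay and not a number. Chloro thus remains the only group here with a readable value, and a second exchange ends at the same ceiling: the limit of > 25000 nM in this assay, at which 2 of the 3 values shown sit.

The step from compound 1 to compound 3 cannot be read, so carbamoyl and tert-butyl stay unranked. From the compounds shown here alone, whether bromo, methoxy or an amine at this place would give a real number remains open.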